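The source may hold more compounds than are shown below. What is called first, only, known or untested is meant among the compounds shown, and "the series" means these compounds.

Compound 1, `Cc1ccccc1CN1CCc2c(sc(NC(=O)c3ccccc3Cl)c2C(N)=O)C1`, in a functional assay on MKN-74 cells (Homo sapiens) for antiproliferative activity, with a stated time of 24 h (a lower number here means a stronger inhibitor, a higher number a weaker inhibitor), gives > 50000 nM; this is a limit of the assay, not a number.
Compound 2, `NC(=O)c1c(NC(=O)c2ccccc2Cl)sc2c1CCN(Cc1ccc([N+](=O)[O-])cc1)C2`, in this assay gives 31500 nM.
Compound 3, `COc1ccc(NC(=S)N2CCc3c(sc(NC(=O)c4ccccc4Cl)c3C(N)=O)C2)cc1`, in this assay gives 19600 nM.

All three share one core, differing only in the group on the ring amine nitrogen. Compound 3 and compound 2 give numbers within the usual scatter of each other, so neither can be called the stronger; compound 1 sits at a limit (the limit of > 50000 nM in this assay, at which 1 of the 3 values shown sits). The step of an at least 2.5-fold lower number from compound 1 to compound 3 (0.40 log units; beyond the scatter) was at least modest, while a 1.6-fold lower number from compound 2 to compound 3 (0.21 log units; within the scatter) stayed within the scatter.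

Compound 4, `NC(=O)c1c(NC(=O)c2ccccc2Cl)sc2c1CCN(C(=O)Nc1c(Cl)cccc1Cl)C2`, is not yet measured. It differs from compound 3 by a group of 11 heavy atoms (7 carbon, 1 nitrogen, 1 oxygen, 2 chlorine; one six-membered aromatic ring of carbon only) in place of a group of 11 heavy atoms (8 carbon, 1 nitrogen, 1 oxygen, 1 sulfur; one six-membered aromatic ring of carbon only), on an amine nitrogen in a ring. Both earlier steps at this position were small or modest, so for this assay a step of a 1.0-fold higher number from compound 3 to compound 4 (0.01 log units; within the scatter) is expected, with no change beyond the scatter. Compound 4 is therefore estimated at 20000 nM, likely between 8000 nM and 50000 nM.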

Compound 4, half-maximal inhibitory concentration: 24400 nM
For compound 4 the middle estimate is 1.2-fold (0.09 log units) below the measured one, within the range that was stated.
By their numbers in this assay, from the lowest: compounds 3, 4 and 2 (each within the scatter of the next). At a limit, above all of these: compound 1.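

In this assay, (2,6-dichlorophenyl)carbamoyl on the ring amine nitrogen cannot be told apart from the group it replaces, with a 1.2-fold higher number from compound 3 to compound 4 (0.10 log units; within the scatter), or from 4-nitrobenzyl, with a 1.3-fold lower number from compound 2 to compound 4 (0.11 log units; within the scatter). Among the compounds shown here, a carbonyl with two chlorines on the aromatic ring therefore does as well here as the sulfur-bearing group of compound 3, which the earlier compounds did not show. Compound 1 stands at a limit, so the step of an at least 2.0-fold lower number from compound 1 to compound 4 (0.31 log units; beyond the scatter) is only a floor: the limit of > 50000 nM in this assay, at which 1 of the 4 values shown sits.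

Going by these compounds, whether plain phenylcarbamoyl, without the two chlorines, or a group carrying a carboxylic acid would fall beyond the scatter of these numbers stays open.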